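A few compounds are considered here, and "the series" means these few. Any claim that something is new, unique, unknown or untested is made for them only; others in the source may bear on it.

Compound 1 `COc1ccc(C(=O)c2ccc(OC)c3c2C=CC(C)(C)O3)c(NC(=O)CO)c1` is the starting point of this small series; in a functional assay on HCT-8 cells (Homo sapiens) for antiproliferative activity, read by MTT assay, with a stated time of 48 h (a higher number here means a weaker inhibitor, a lower number a stronger inhibitor), compound 1 gives 630 nM. Compound 2 `COc1ccc(C(=O)c2ccc(OC)c3c2C=CC(C)(C)O3)c(NC(=O)CN)c1` carries amino in place of hydroxy on a saturated chain carbon bound to a carbonyl carbon and in this assay compound 2 gives 1050 nM, so that the step of a 1.7-fold higher number from compound 1 to compound 2 (0.22 log units; within the scatter) is recorded. Compound 3 `C=C(c1ccc(OC)cc1NC(=O)CO)c1ccc(OC)c2c1C=CC(C)(C)O2` has a different core; how the core of compound 3 differs from that of compound 1 is not broken down here. In this assay compound 3 gives 470 nM. Compound 4 `C=C(c1ccc(OC)cc1NC(=O)CN)c1ccc(OC)c2c1C=CC(C)(C)O2` is not yet measured and stands to compound 3 as compound 2 stands to compound 1: amino in place of hydroxy on a saturated chain carbon bound to a carbonyl carbon. Since compound 1 and compound 2 showed a 1.7-fold higher number from compound 1 to compound 2 (0.22 log units; within the scatter), a similar step a 1.7-fold higher number from compound 3 to compound 4 (0.23 log units; within the scatter) is expected in this assay on the second core. Compound 4 is therefore estimated at 800 nM, with a likely range from 400 nM to 1600 nM.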

Compound 4, half-maximal inhibitory concentration: 520 nM
For compound 4 the middle estimate is 1.5-fold (0.19 log units) above the measured one, and the stated range covers the measured number.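

In this assay, amino in place of hydroxy on a saturated chain carbon bound to a carbonyl carbon gives a 1.1-fold higher number from compound 3 to compound 4 (0.04 log units; within the scatter) on the core of compound 3, and the comparison with the core of compound 1 reads: the same change on two cores in this assay, a 1.7-fold higher number (0.22 log units; within the scatter) from compound 1 to compound 2 and a 1.1-fold higher number (0.04 log units; within the scatter) from compound 3 to compound 4, 1.5-fold (0.18 log units) apart, within the scatter of two such steps. On these two cores, then, the change carries over in the sense that neither step lies beyond the scatter and the two steps cannot be told apart. This does not show that the change would behave alike on any other core, and two pairs of compounds establish no general rule.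

The compounds shown leave open how a longer chain, a carboxylic acid or a dimethylamino group would fare in place of the hydroxy or amino group. From the compounds shown here alone, whether the same holds in other cell types also remains open.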